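Aryl variation on the amide-type nitrogen of the shared core

The source may hold more compounds than are shown below. What is called first, only, known or untested is meant among the compounds shown, and "the series" means these compounds.

Three measured compounds share a core and differ only in the aryl group on an amide-type nitrogen in a ring. In a functional assay on U2OS cells (Homo sapiens) for inhibition, read by CCK-8 assay, with a stated time of 72 h, tested at 1 uM (on this read-out higher numbers stand for more inhibition at the one concentration tested (going by the name of the read-out) and lower numbers for less inhibition), compound 1 `COc1ccc(OC)c(N2C(=O)CSC2c2cccc(C(=O)NCCCCc3ccccc3)c2)c1` gives 1%, compound 2 `O=C(NCCCCc1ccccc1)c1cccc(C2SCC(=O)N2c2ccccc2)c1` gives 68%, and compound 3 `COc1cc(F)ccc1N1C(=O)CSC1c1cccc(C(=O)NCCCCc2ccccc2)c1` gives 34%. Compound 3 thus stands second highest of the three: a number 33 percentage points higher from compound 1 to compound 3 (beyond the scatter) and a number 34 percentage points lower from compound 2 to compound 3 (beyond the scatter). Compound 4 `COc1c(F)cccc1N1C(=O)CSC1c1cccc(C(=O)NCCCCc2ccccc2)c1` differs from compound 3 by 3-fluoro-2-methoxyphenyl in place of 4-fluoro-2-methoxyphenyl on an amide-type nitrogen in a ring. Within the data shown here, no measured step moves the fluorine within the same aryl group; the steps of a number 67 percentage points higher from compound 1 to compound 2 (beyond the scatter), a number 33 percentage points higher from compound 1 to compound 3 (beyond the scatter) and a number 34 percentage points lower from compound 2 to compound 3 (beyond the scatter) each exchange the whole aryl group and were large, so this assay is sensitive to that group, but they give no direction for this change. The step of a number 1 percentage points higher from compound 3 to compound 4 (within the scatter) is therefore expected to stay within the scatter. The estimate for compound 4 is 35%, between 12% and 58%.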

Compound 4, a percentage reported as inhibition, at one concentration (the size of the read-out at that concentration, not a potency): 12%
Estimate against measurement, compound 4: 23 percentage points above; the measured number falls inside the stated range.
By their numbers in this assay, from the lowest: compound 1; then compound 4; then compound 3; then compound 2.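

In this assay the place of the fluorine itself counts, with a number 22 percentage points lower from compound 3 to compound 4 (beyond the scatter) even though the two aryl groups have the same atoms, something the whole-group exchanges could not show. The 3-fluoro-2-methoxyphenyl group stays well short of plain phenyl, with a number 56 percentage points lower from compound 2 to compound 4 (beyond the scatter) as the drop, yet retains a small margin over 2,5-dimethoxyphenyl, with a number 11 percentage points higher from compound 1 to compound 4 (beyond the scatter) as the gain. No available evidence accounts for the effect of moving the fluorine.

As far as these compounds go, how 2-methoxyphenyl or 3-fluorophenyl alone would compare with plain phenyl remains open. So does the response to an amine or a carboxylic acid on this aryl ring.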